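Halogen for methyl on the pyrazole nitrogen aryl group

A few compounds are considered here, and "the series" means these few. Any claim that something is new, unique, unknown or untested is made for them only; others in the source may bear on it.

Three compounds share a core and were tested in a functional assay on DU-145 cells (Homo sapiens) for cytotoxicity, read by MTT assay, with a stated time of 48 h; on this read-out higher numbers stand for weaker inhibition and lower numbers for stronger inhibition. Compound 1 `CCOC(=O)c1c(-c2c(Cl)c3ccccc3oc2=O)nn(-c2cccc(C)c2)c1C(=O)OCC` gives 32000 nM; compound 2 `CCOC(=O)c1c(-c2c(Cl)c3cc(C)ccc3oc2=O)nn(-c2cccc(Cl)c2)c1C(=O)OCC` gives 156000 nM; compound 3 `CCOC(=O)c1c(-c2cc3ccccc3oc2=O)nn(-c2cccc(C)c2)c1C(=O)OCC` gives 47000 nM, the second highest number of the three, close to compound 1 and furthest from compound 2. Among the compounds with values here, the only single-point step measured is a 1.5-fold higher number from compound 1 to compound 3 (0.17 log units; within the scatter). Compound 4 `CCOC(=O)c1c(-c2cc3ccccc3oc2=O)nn(-c2ccc(Br)cc2)c1C(=O)OCC` differs from compound 3 by 4-bromophenyl in place of 3-methylphenyl on an aromatic nitrogen. Within the data shown here, no measured step changes this aryl group alone, so the comparison rests on little: compound 2 carries a chloro on that ring and shows a higher number than compound 1, but it differs in two places. Compound 4 is therefore expected to show a 1.2-fold higher number from compound 3 to compound 4 (0.07 log units; within the scatter), with an estimate of 55000 nM between 15000 nM and 200000 nM.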

Compound 4, half-maximal inhibitory concentration: 61000 nM
The estimate for compound 4 lay 1.1-fold (0.04 log units) below the measured number; the range from low to high includes it.
By their numbers in this assay, from the lowest: compounds 1, 3 and 4 (each within the scatter of the next); then compound 2.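

In this assay, the first direct test of this aryl group gives a 1.3-fold higher number from compound 3 to compound 4 (0.11 log units; within the scatter), so 4-bromophenyl and 3-methylphenyl cannot be told apart on this aromatic nitrogen. Because this one step exchanges both the ring's substituent and where it sits, it cannot separate those two differences. No available evidence bears on this result. The compounds shown leave open how an amine or a carboxylic acid on this aryl ring would read. They also leave open what a longer alkyl chain in place of the ring would give.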